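Benzoyl in place of carbamoyl on an enaminonitrile side chain

The source may hold more compounds than are shown below. What is called first, only, known or untested is meant among the compounds shown, and "the series" means these compounds.

Measured so far:
compound 1 `N#C/C(=C\N1CCN(C(=O)c2ccco2)C1=S)C(N)=O` gives 14000 nM;
compound 2 `O=CN1CCN(C(=O)c2ccco2)C1=S` gives 5000 nM;
compound 3 `O=CN1CCN(c2cc(Cl)cc(Cl)c2)C1=S` gives 15800 nM.

In a functional assay on UACC-62 cells (Homo sapiens) for inhibition, read by sulforhodamine B assay, with a stated time of 48 h (a higher number here means a weaker inhibitor of growth, a lower number a stronger inhibitor of growth), compound 1 stands second highest of the three numbers. Compound 3 lies within the usual scatter of it, so the two cannot be told apart; compound 2, however, gives a clearly lower number than compound 1, beyond the scatter, and so inhibits growth more strongly. Compound 4 `N#C/C(=C\N1CCN(C(=O)c2ccco2)C1=S)C(=O)c1ccccc1` has not yet been measured in this assay. It differs from compound 1 in one place: phenyl in place of amino on a carbonyl carbon. Among the measured compounds shown here, no measured pair shows the effect of such a change here. A small step is expected for compound 4, estimated as a 1.6-fold lower number from compound 1 to compound 4 (0.19 log units; within the scatter), likely not beyond the scatter. Compound 4 is therefore expected to give about 9000 nM, somewhere between 2500 nM and 32000 nM.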

Compound 4, concentration for 50% growth inhibition: 12900 nM
Beside the measured number, compound 4's estimate is 1.4-fold (0.16 log units) below it; low and high end bracket the measured number.
By their numbers in this assay, from the lowest: compound 2; then compounds 4, 1 and 3 (each within the scatter of the next).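

Read in this assay, the swap of carbamoyl for benzoyl gives a 1.1-fold lower number from compound 1 to compound 4 (0.04 log units; within the scatter), a step within the scatter. At this carbonyl carbon, then, the amino group with its hydrogen-bond donor and a phenyl ring with none cannot be told apart, despite the larger group's six carbon atoms. Nothing available explains why the two compounds read alike.

Still open, going by these compounds, is whether a carboxylic acid or a dimethylamino group at this carbonyl carbon would also leave the number within the scatter. On these data alone, it is equally open whether a chlorine on the phenyl ring would shift it.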